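Branching the alkyl chain of a weak guanidine inhibitor

This account rests on a few compounds, and the source may have more. Where it says the series, first, only, none or still open, it means among the compounds named here.

Compound 2 `CCCCCNC(=N)NCCOC` is the weaker of the two compounds measured in an assay on cells for inhibition of N(G),N(G)-dimethylarginine dimethylaminohydrolase 1 (Homo sapiens), with a stated time of 30 min; on this read-out lower numbers stand for stronger inhibition and higher numbers for weaker inhibition: compound 2 gives 2820000 nM, the higher of the two numbers. Its neighbour compound 1 `COCCNC(=N)NCCCCC(=O)O` gives 489000 nM, and the step of a 5.8-fold higher number from compound 1 to compound 2 (0.76 log units; beyond the scatter) separates them. Compound 3 `COCCNC(=N)NCCC(C)C` differs from compound 2 by isopropyl in place of propyl on a saturated chain carbon, two bonds along the chain from an amine nitrogen. Among the compounds with values here, no measured step bears on this change: the only step recorded, a 5.8-fold higher number from compound 1 to compound 2 (0.76 log units; beyond the scatter), concerns the exchange of a carboxy group for a methyl group and says nothing about branching of an alkyl chain that keeps the same atoms. With no comparison to lean on, the step of a 1.0-fold lower number from compound 2 to compound 3 (0.00 log units; within the scatter) is expected to stay within the scatter, in no particular direction. Compound 3 is therefore estimated at 2800000 nM in this assay, with a range from 1000000 nM to 8000000 nM.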

Compound 3, inhibition constant: 2760000 nM
Estimate against measurement, compound 3: 1.0-fold (0.01 log units) above, within the range that was stated.
By their numbers in this assay, from the lowest: compound 1; then compounds 3 and 2 (each within the scatter of the next).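

In this assay, isopropyl in place of propyl gives a 1.0-fold lower number from compound 2 to compound 3 (0.01 log units; within the scatter), so on a saturated chain carbon, two bonds along the chain from an amine nitrogen, this rearrangement of the same atoms does not separate compound 2 from compound 3. Isopropyl in place of 2-carboxyethyl gives a 5.6-fold higher number from compound 1 to compound 3 (0.75 log units; beyond the scatter), which shows that compound 1 stands apart from the branched compound as well as from the unbranched one. No supporting evidence accompanies this result to account for it.

The compounds shown leave open whether a longer chain or a cyclohexyl group at this place would move the number beyond the scatter. They also leave open how an amine at the chain end would compare with the carboxylic acid of compound 1.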